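Bromo to cyano on a sugar-linked hydrazone core

The source may hold more compounds than are shown below. What is called first, only, known or untested is meant among the compounds shown, and "the series" means these compounds.

Measured compounds:
- compound 1, `CC(=O)C[C@H]1O[C@@H](On2cc(CN3C(=O)/C(=N\Nc4ccc(Br)cc4)c4ccccc43)nn2)[C@H](OC(C)=O)[C@@H](OC(C)=O)[C@@H]1OC(C)=O`: 116000 nM
- compound 2, `CC(=O)C[C@H]1O[C@@H](On2cc(CN3C(=O)/C(=N\Nc4ccc(C#N)cc4)c4ccccc43)nn2)[C@H](OC(C)=O)[C@@H](OC(C)=O)[C@H]1OC(C)=O`: 75500 nM
- compound 3, `CC1(C)O[C@H]2O[C@H](Cn3cc(CN4C(=O)/C(=N\Nc5ccc(Br)cc5)c5ccccc54)nn3)[C@H](O)[C@H]2O1`: 72900 nM

All three values come from an ADME assay on Vero cells (Chlorocebus sabaeus) for cytotoxicity, read by fluorescence and resazurin assay, with a stated time of 3 days; on this read-out higher numbers stand for lower toxicity in this test and lower numbers for higher toxicity in this test. Compound 1 gives 116000 nM, compound 2 gives 75500 nM, and compound 3 gives 72900 nM. The gaps between these numbers are within the usual scatter of this assay, so none of the three can be called more or less toxic than the others; compound 3 sits alongside compound 2 and compound 1 rather than apart from them.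

Compound 4, `CC1(C)O[C@H]2O[C@H](Cn3cc(CN4C(=O)/C(=N\Nc5ccc(C#N)cc5)c5ccccc54)nn3)[C@H](O)[C@H]2O1`, is not yet measured. It differs from compound 3 in one place: cyano in place of bromo on an aromatic carbon. Among the compounds with values here, no measured pair shows exactly this step on a shared core, so no direct precedent exists for its size. Compound 1 and compound 2 carry the same two end groups on a related core, and their values lie within the scatter of each other, which gives no sign of a large effect in either direction. For compound 4 the step of a 1.0-fold lower number from compound 3 to compound 4 (0.02 log units; within the scatter) is therefore expected to be small, not beyond the scatter. Compound 4 is estimated at 70000 nM, with a range from 35000 nM to 140000 nM.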

Compound 4, half-maximal cytotoxic concentration: 105000 nM
Beside the measured number, compound 4's estimate is 1.5-fold (0.18 log units) below it; low and high end bracket the measured number.
By their numbers in this assay, from the lowest: compounds 3, 2, 4 and 1 (each within the scatter of the next).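

In this assay, within the data shown here, swapping 4-bromophenyl for 4-cyanophenyl on the shared core gives a 1.4-fold higher number from compound 3 to compound 4 (0.16 log units; within the scatter) as the first direct reading of this change alone. On this aromatic carbon, para to a large group, cyano can therefore take the place of bromo with no difference that this test can separate from its scatter, even though cyano brings a triple bond and a hydrogen-bond acceptor that bromo lacks. No supporting data are available to explain this result.

The compounds shown leave open whether this position would tolerate a very different group, such as an amine, a carboxylic acid or a longer chain, equally well. They also do not show whether plain hydrogen on this carbon would give a similar reading.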